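A few compounds are considered here, and "the series" means these few. Any claim that something is new, unique, unknown or untested is made for them only; others in the source may bear on it.

Compound 1 `O=c1[nH]cc(-c2ccccc2)o1` is the bare core of this series, and in an assay on isolated protein for inhibition of acid ceramidase (Homo sapiens), read by LC-MS, with a stated time of 1 h (on this read-out lower numbers stand for stronger inhibition and higher numbers for weaker inhibition), compound 1 is recorded only as "not active" (no number reported). Compound 2 `COc1ccc(-c2cn(C(=O)NCCCCc3ccccc3)c(=O)o2)cc1` carries a carbamate chain on the ring nitrogen and a 4-methoxyphenyl group; in this assay compound 2 gives 400 nM, which is the only numerical result shown, so it is the sole reference point. Compound 3 `O=C(NCCCCc1ccccc1)n1cc(-c2cccnc2)oc1=O` differs from compound 2 in one place: pyridin-3-yl in place of 4-methoxyphenyl on an aromatic carbon. For the measured compounds named here, no measured pair shows what such an exchange does, so the expectation rests on the single number for compound 2 alone. The step from compound 2 to compound 3 is expected to be modest and toward weaker inhibition, roughly a 2.3-fold higher number from compound 2 to compound 3 (0.35 log units; beyond the scatter), with a real chance it falls inside the scatter. Compound 3 is therefore estimated at 900 nM, with a range from 300 nM to 3000 nM.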

Compound 3, half-maximal inhibitory concentration: 70 nM
Compound 3: middle estimate off by 13-fold (1.11 log units), on the high side; measured number outside the range, below it.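

In this assay, putting pyridin-3-yl in place of 4-methoxyphenyl on the aromatic carbon next to the ring oxygen gives a 5.7-fold lower number from compound 2 to compound 3 (0.76 log units; beyond the scatter), which means stronger inhibition and a step beyond the scatter. This position therefore responds clearly to the group it carries, and 4-methoxyphenyl is not needed there, since an aromatic ring with a ring nitrogen and no methoxy group does better. Nothing measured here explains why this exchange helps.

The exchange changes two things at once, adding a ring nitrogen and removing the methoxy group, so a plain phenyl group at this carbon with the same chain would be needed to tell them apart. As far as these compounds go, how much the four-carbon phenylbutyl chain matters also stays open, and a shorter chain on the same carbamate would test that.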